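Swapping a Furan for an Imidazole on the Aryl Ring

The source may hold more compounds than are shown below. What is called first, only, known or untested is meant among the compounds shown, and "the series" means these compounds.

Two measured compounds share a core in which a six-membered carbon ring carries an ether-linked group. Compound 1 `CCN(CC)C(=O)c1ccccc1OCC1=NCCN1` bears a diethylamide on that ring. In a functional assay for activation of Alpha-1A adrenergic receptor (Homo sapiens), read by calcium flux (a lower number here means that less compound is needed, a higher number that more compound is needed for the effect), compound 1 reaches only a limit of the assay, < 5020 nM. Compound 2 `c1coc(-c2ccccc2OCC2=NCCN2)c1` bears a furan-2-yl there instead, and in this assay compound 2 gives 1.26 nM. That is the only real number shown; the other value is a limit (the limit of < 5020 nM in this assay, at which 1 of the 2 values shown sits), so compound 2 cannot be ranked against compound 1. Compound 3 `c1ccc(-c2ncc[nH]2)c(OCC2=NCCN2)c1` differs from compound 2 in one place: 1H-imidazol-2-yl in place of furan-2-yl on an aromatic carbon. Among the compounds with values here, no measured pair differing in a single place exists, so the size of this step rests on expectation alone. The step is expected to go upward, beyond the usual scatter, at a 7.9-fold higher number from compound 2 to compound 3 (0.90 log units; beyond the scatter). Compound 3 is estimated at 10 nM in this assay, within a range from 1.5 nM to 60 nM.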

Compound 3, half-maximal effective concentration: 100 nM
Beside the measured number, compound 3's estimate is 10-fold (1.00 log units) below it; the measured number lies above the stated range.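

This is the only pair shown that differs in one place, so it gives the change a measured size: in this assay, 1H-imidazol-2-yl in place of furan-2-yl means a 79-fold higher number from compound 2 to compound 3 (1.90 log units; beyond the scatter) at this position on the aromatic carbon. Both groups are five-membered aromatic rings with the same heavy-atom count, so this position does not treat all such rings alike in this assay. Nothing measured here explains the step or shows whether the oxygen leaving, the nitrogens entering or the hydrogen-bond donor matters most.

Still open, on these data alone, is how a thiophen-2-yl ring, a plain phenyl ring or a simple amine at this position would compare with these two groups. A single pair also leaves open whether the same swap would give a similar step on another core.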